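Carbamoyl in Place of (Benzyloxycarbonyl)methyl on the Side Chain

The source may report more compounds than this note shows. Statements on the series, on what has been measured and on what is new or still open speak of the compounds shown alone.

Measured in a functional assay on the whole organism (Tail, strain ICR) with Mus musculus as the target, in the tail flick test, with a stated time of 60 min, at a dose of 25 umol/kg by the oral route; a higher number here means a stronger effect of the compound at the dose given, a lower number a weaker effect:
compound 1 `O=C(CN(c1ncnc2c1ncn2C1CCCCO1)C1CC1)NCC(=O)OCc1ccccc1`: 40.4%
compound 2 `O=C(CN(c1nc(Cl)nc2[nH]cnc12)C1CC1)N[C@@H](CCC(=O)OCc1ccccc1)C(=O)OCc1ccccc1`: 53.7%

Compound 2 gives the higher of the two numbers; compound 1 sits lower by a gap that lies beyond the usual scatter. Compound 3 `NC(=O)C[C@H](NC(=O)CN(c1nc(Cl)nc2[nH]cnc12)C1CC1)C(=O)OCc1ccccc1` is not yet measured. It differs from compound 2 in one place: carbamoyl in place of (benzyloxycarbonyl)methyl on a saturated chain carbon, two bonds along the chain from an amide-type nitrogen and a carbonyl carbon. For the measured compounds named here, no step between measured compounds covers this change, so the expected size of the step in this assay rests on the structural change alone. A modest drop is expected, a number 8.7 percentage points lower from compound 2 to compound 3 (within the scatter), with room for no change beyond the scatter. Compound 3 is estimated at 45%, between 22% and 68%.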

Compound 3, a percentage reported as activity, at one dose (the size of the read-out at that dose, not a potency): 36.4%
Compound 3: the middle estimate sits 8.6 percentage points above what was measured, within the range that was stated.
By their numbers in this assay, from the lowest: compounds 3 and 1 (each within the scatter of the next); then compound 2.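

In this assay, for the compounds shown here, the side chain position proves sensitive: carbamoyl in place of (benzyloxycarbonyl)methyl gives a number 17.3 percentage points lower from compound 2 to compound 3 (beyond the scatter) and thus the first reading of a single change here, since the earlier compounds differ in more than one place. Nothing measured accounts for the step.

The change removes the aromatic ring and shortens the group at once, so the compounds shown do not separate these two differences. As far as these compounds go, a carboxylic acid, an amine or a longer chain ending in carbamoyl at this carbon remains open.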